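Chloro-isomer swap on the hydrazide aryl ring, second pair

A few compounds are considered here, and "the series" means these few. Any claim that something is new, unique, unknown or untested is made for them only; others in the source may bear on it.

Four compounds of one series, all carrying a sulfonamide-linked heterocycle and an aryl hydrazide. Compound 1 has the structure `O=C(NNc1ccccc1Cl)c1ccc(NS(=O)(=O)c2cnc(O)nc2O)cc1` and compound 2 the structure `O=C(NNc1cccc(Cl)c1)c1ccc(NS(=O)(=O)c2cnc(O)nc2O)cc1`. In a functional assay on OVCAR-3 cells (Homo sapiens) for antiproliferative activity, read by MTT assay, with a stated time of 24 h (a higher number here means a weaker inhibitor, a lower number a stronger inhibitor), compound 1 gives 7230 nM, while compound 2 gives 8410 nM. The change between the two is 3-chlorophenyl in place of 2-chlorophenyl on an amine nitrogen and it made a step of a 1.2-fold higher number from compound 1 to compound 2 (0.07 log units; within the scatter).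

Compound 3, structure `O=C(NNc1ccccc1Cl)c1ccccc1NS(=O)(=O)c1cnc(O)nc1O`, has a core that differs from the core of compound 1 in more than one place; that difference is not broken down here. In this assay compound 3 gives 14100 nM, and among the three measured values it stands within the scatter of both compound 1 and compound 2.

Compound 4, structure `O=C(NNc1cccc(Cl)c1)c1ccccc1NS(=O)(=O)c1cnc(O)nc1O`, is not yet measured. It differs from compound 3 by 3-chlorophenyl in place of 2-chlorophenyl on an amine nitrogen. Within the data shown here, the change sits on the same kind of position as the one from compound 1 to compound 2, on an amine nitrogen whose other neighbour is an amide-type nitrogen, so the two pairs carry the same change on two different cores.

Among the measured compounds shown here, the expectation for compound 4 rests on the single earlier instance of this change: because the step of a 1.2-fold higher number from compound 1 to compound 2 (0.07 log units; within the scatter) was small, a similarly small step a 1.2-fold higher number from compound 3 to compound 4 (0.07 log units; within the scatter) is expected here. Compound 4 is therefore estimated in this assay at 16500 nM, with a likely range from 8500 nM to 32000 nM; a single prior pair is a thin basis and the range is set wide.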

Compound 4, half-maximal inhibitory concentration: 5520 nM
Compound 4: the middle estimate sits 3.0-fold (0.48 log units) above what was measured, and the stated range ends above it.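

In this assay, 3-chlorophenyl in place of 2-chlorophenyl on the amine nitrogen gives a 2.6-fold lower number from compound 3 to compound 4 (0.41 log units; beyond the scatter) and does not repeat the size of the step seen with the same change on the core of compound 1: the same change on two cores in this assay, a 1.2-fold higher number (0.07 log units; within the scatter) from compound 1 to compound 2 and a 2.6-fold lower number (0.41 log units; beyond the scatter) from compound 3 to compound 4, 3.0-fold (0.47 log units) apart, beyond the scatter of two such steps.

The effect of this change therefore depends on the core within these two pairs, and a step read on one of these cores is a poor guide to the same change on the other. Among these compounds, this does not show which difference between the cores is responsible or why the two steps part, and with only one pair on each core it gives no general rule for the series, only a single modest step beyond the scatter set against one within it.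

Still open, as far as these compounds go, is whether the same dependence on the core appears when the chlorine on the aryl ring is replaced by a bromine, a methyl or a methoxy group, or when the aryl ring carries no substituent at all. Also open, from the compounds shown here alone, is whether the two cores part in the same way in cell lines other than the one used here, or with longer exposure.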